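The source may report more compounds than this note shows. Statements on the series, on what has been measured and on what is new or still open speak of the compounds shown alone.

Compound 1 `COc1cc(/C=C/C(=O)c2cccc(NC(=O)c3ccc(Cl)c(Cl)c3)c2)ccc1O` gives 45% in a functional assay on HUVEC cells (Homo sapiens) for inhibition, tested at 10 ug/mL; a higher number here means a stronger effect of the compound at the concentration tested, a lower number a weaker effect.
Compound 2 `COc1cc(/C=C/C(=O)c2cccc(N)c2)ccc1O` gives 90% in this assay.
Compound 3 `COc1cc(/C=C/C(=O)c2cccc(NC(=O)c3ccccc3)c2)ccc1O` gives 69% in this assay.

Among these three, compound 1 stands lowest: a number 24 percentage points higher from compound 1 to compound 3 (beyond the scatter), and a number 45 percentage points higher from compound 1 to compound 2 (beyond the scatter). Compound 4 `CCOC(=O)C(=O)Nc1cccc(C(=O)/C=C/c2ccc(O)c(OC)c2)c1` is not yet measured. It differs from compound 1 in one place: ethoxycarbonyl in place of 3,4-dichlorophenyl on a carbonyl carbon. Within the data shown here, two measured steps bear on this. Replacing the 3,4-dichlorophenyl by a plain phenyl gave a modest rise, a number 24 percentage points higher from compound 1 to compound 3 (beyond the scatter); removing the whole acyl group gave a large one, a number 45 percentage points higher from compound 1 to compound 2 (beyond the scatter). Compound 4 also loses the 3,4-dichlorophenyl but keeps an amide, so a modest rise in this assay is expected rather than a large one. The estimate for compound 4 is 65%, within 40% to 85%, an expected step of a number 20 percentage points higher from compound 1 to compound 4 (beyond the scatter).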

Compound 4, a percentage reported as inhibition, at one concentration (the size of the read-out at that concentration, not a potency): 66%
For compound 4 the middle estimate is 1 percentage points below the measured one, within the range that was stated.
By their numbers in this assay, from the lowest: compound 1; then compounds 4 and 3 (each within the scatter of the next); then compound 2.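

Swapping 3,4-dichlorophenyl for ethoxycarbonyl on this carbonyl carbon gives a number 21 percentage points higher from compound 1 to compound 4 (beyond the scatter), so the gain seen with plain phenyl is also reached with a group that has no ring. Ethoxycarbonyl and phenyl cannot be told apart here, with a number 3 percentage points lower from compound 3 to compound 4 (within the scatter), yet the acylated nitrogen still falls short of the free amine, with a number 24 percentage points lower from compound 2 to compound 4 (beyond the scatter). Nothing available explains these differences. Open, from the compounds shown here alone, is what ethoxycarbonyl itself contributes: a carboxylic acid or a longer chain in its place would test whether this part matters.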